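The source may hold more compounds than are shown below. What is called first, only, known or untested is meant among the compounds shown, and "the series" means these compounds.

Measured so far in a functional assay on cells (Cancer cell lines, Homo sapiens) for cytotoxicity, read by sulforhodamine B assay, with a stated time of 48 h; a higher number here means a weaker inhibitor of growth, a lower number a stronger inhibitor of growth:
Compound 1 `NS(=O)(=O)c1ccc(-n2nc(-c3ccc(Cl)cc3)cc2-c2cc(O)ccc2O)cc1` gives 54500 nM.
Compound 2 `CC(=O)NS(=O)(=O)c1ccc(-n2nc(-c3ccccc3)cc2-c2cc(O)ccc2O)cc1` gives 100000 nM.
Compound 3 `NS(=O)(=O)c1ccc(-n2nc(-c3ccc(Cl)cc3)cc2C2=CC(=O)C=CC2=O)cc1` gives 62600 nM.

Compound 1 and compound 3 differ in one place only: a group of 8 heavy atoms (6 carbon, 2 oxygen; one six-membered non-aromatic ring of carbon only) in place of a group of 8 heavy atoms (6 carbon, 2 oxygen; one six-membered aromatic ring of carbon only), on an aromatic carbon. This change produced a 1.1-fold higher number from compound 1 to compound 3 (0.06 log units; within the scatter), so the two compounds cannot be told apart on this read-out. Compound 2 shares much of its build with compound 1, but the difference between the two cores is not broken down here; its value and those of compound 1 and compound 3 all lie within the usual scatter of one another.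

Compound 4 `CC(=O)NS(=O)(=O)c1ccc(-n2nc(-c3ccccc3)cc2C2=CC(=O)C=CC2=O)cc1` has not yet been measured. It stands to compound 2 as compound 3 stands to compound 1: a group of 8 heavy atoms (6 carbon, 2 oxygen; one six-membered non-aromatic ring of carbon only) in place of a group of 8 heavy atoms (6 carbon, 2 oxygen; one six-membered aromatic ring of carbon only), on an aromatic carbon. The surroundings are not identical, since in compound 2 the neighbouring ring atom bears a large group and the atom two ring bonds away bears a phenyl group, whereas in compound 1 those atoms bear a 4-sulfamoylphenyl group and a 4-chlorophenyl group, so this is the same kind of change rather than the same change.

The step from compound 2 to compound 4 is expected to be small, about no change at the digits printed from compound 2 to compound 4 (within the scatter), because a 1.1-fold higher number from compound 1 to compound 3 (0.06 log units; within the scatter) was within the scatter. Compound 4 is therefore estimated at 100000 nM in this assay, expected to fall between 50000 nM and 200000 nM.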

Compound 4, concentration for total growth inhibition: 100000 nM
Beside the measured number, compound 4's estimate shows no gap at the digits printed; low and high end bracket the measured number.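

In this assay, putting the non-aromatic ring in place of the 2,5-dihydroxyphenyl group gives no change at the digits printed from compound 2 to compound 4 (within the scatter), and the two cores can be compared directly: the same change on two cores in this assay, a 1.1-fold higher number (0.06 log units; within the scatter) from compound 1 to compound 3 and no change at the digits printed (within the scatter) from compound 2 to compound 4, 1.1-fold (0.06 log units) apart, within the scatter of two such steps. On these two cores, then, the change carries over in the same way, leaving the read-out no different from that of the parent compound each time. For the compounds shown here, this does not show that the change would be just as silent on other cores, as only two pairs are at hand, and two steps this small say nothing about a core on which the swap might matter.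

The compounds shown leave open what other groups would do at this place on the five-membered ring, for example a plain phenyl ring without hydroxyl groups, or a ring bearing an amine or a carboxylic acid. Also open are the separate effects of the chlorine on the phenyl ring and the acetyl group on the sulfonamide, as no pair shown changes only one of them.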